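A Methyl on the Saturated Ring and Cytotoxicity Outlook

This account rests on a few compounds, and the source may have more. Where it says the series, first, only, none or still open, it means among the compounds named here.

compound 1 `CN(CC1(C)CCn2cc([N+](=O)[O-])nc2O1)c1ccc(F)cc1` — >= 40000 nM
compound 2 `O=C(NCC1CCn2cc([N+](=O)[O-])nc2O1)Nc1ccc(OC(F)(F)F)cc1` — >= 40000 nM

Both were tested in an ADME assay on MRC5 cells (Homo sapiens) for cytotoxicity, read by resazurin assay, with a stated time of 72 h; a higher number here means a weaker inhibitor, a lower number a stronger inhibitor. For compound 1 the figure >= 40000 nM is a limit of the assay, not a number. For compound 2 the figure >= 40000 nM is likewise a limit. Compound 2 thus stands at the limit of >= 40000 nM in this assay, at which 2 of the 2 values shown sit. Compound 3 `CC1(CNC(=O)Nc2ccc(OC(F)(F)F)cc2)CCn2cc([N+](=O)[O-])nc2O1` differs from compound 2 by methyl in place of hydrogen on a saturated ring carbon. Among the compounds with values here, no measured step of this kind is known; no shift beyond the scatter is expected, so the expected step that the limit leaves unreadable from compound 2 to compound 3 is essentially none. Compound 3 is therefore expected to give 45000 nM, within 20000 nM to 100000 nM.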

Compound 3, half-maximal inhibitory concentration: >= 40000 nM
Compound 3 was reported as a limit; the forecaster's own chance of this, stated with the estimate: 80%; the middle value lies beyond the limit too.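

No step can be read from compound 2 to compound 3, because both are reported only as limits: the limit of >= 40000 nM in this assay, at which 3 of the 3 values shown sit.

The compounds shown leave open whether methyl in place of hydrogen on a saturated ring carbon shifts the true value in this assay at all.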